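A few compounds are considered here, and "the series" means these few. Any claim that something is new, unique, unknown or untested is made for them only; others in the source may bear on it.

Values in an ADME assay on Huh-7 cells (Homo sapiens) for cytotoxicity (a higher number here means that more compound is tolerated, a lower number that less compound is tolerated), each one a limit of the assay and not a number:

- compound 1 `O=C(c1nc2sccn2c1Cl)N1CCN(C2CCCC2)C(=O)C1` gives > 10000 nM
- compound 2 `Cc1cn2c(Cl)c(C(=O)N3CCN(C4CCCC4)C(=O)C3)nc2s1` gives > 10000 nM
- compound 3 `CC(C)c1cn2c(Cl)c(C(=O)N3CCN(C4CCCC4)C(=O)C3)nc2s1` gives > 10000 nM

Compound 3 therefore has no exact value, only a limit, and it shares that position with the other two compounds. The evidence so far comes down to the limit of > 10000 nM in this assay, at which 3 of the 3 values shown sit.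

Compound 4 `Cc1c(C(C)C)sc2nc(C(=O)N3CCN(C4CCCC4)C(=O)C3)c(Cl)n12` is made from compound 3 by putting a methyl in place of hydrogen on an aromatic carbon, next to the ring nitrogen and next to the ring atom that bears an isopropyl group: methyl in place of hydrogen on an aromatic carbon.

The closest measured change of the same kind is a step that the two limits leave unreadable from compound 1 to compound 2. Two further steps also add carbon to the same site or enlarge a group there: a step that the two limits leave unreadable from compound 1 to compound 3 and a step that the two limits leave unreadable from compound 2 to compound 3. None of these steps has a size that can be read, so they point in no direction. No step beyond the usual scatter is expected in this assay, and another limit is the likeliest report.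

The expected change is a step that the limit leaves unreadable from compound 3 to compound 4. For compound 4 the estimated value is 14000 nM, with an expected range from 6000 nM to 30000 nM.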

Compound 4, half-maximal cytotoxic concentration: > 10000 nM
Compound 4: no number, only a limit (the forecaster's own chance of this, stated with the estimate: 85%); the middle value does not contradict the limit.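

In this assay compound 4 gives > 10000 nM, which is a limit of the assay and not a number. Compound 3 also has only a limit, so the step between compound 3 and compound 4 cannot be read. The compounds shown leave open how much of any of them is tolerated, and whether the added methyl changes that, as all the evidence comes down to one point: the limit of > 10000 nM in this assay, at which 4 of the 4 values shown sit.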